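The source may hold more compounds than are shown below. What is called first, only, known or untested is meant among the compounds shown, and "the series" means these compounds.

Measured so far:
- Compound 1, `COc1ccc(NC(=O)c2c(O)c3cccnc3n(-c3ccccc3)c2=O)cc1`: -1.9%
- Compound 2, `O=C(Nc1cccc([N+](=O)[O-])c1)c1c(O)c2cccnc2n(-c2ccccc2)c1=O`: 7.4%

In a functional assay on the whole organism for inhibition, with Rattus norvegicus as the target, read by cytopathic effect and paw edema, at a dose of 100 mg/kg by the oral route (on this read-out lower numbers stand for less inhibition and higher numbers for more inhibition at the one dose given (going by the name of the read-out)), compound 1 gives -1.9%, the lowest of the two numbers. Compound 2 gives 7.4% in the same test. For the measured compounds named here, the only measured step, a number 9.3 percentage points higher from compound 1 to compound 2 (within the scatter), lies within the scatter, so the two numbers cannot be told apart and neither compound can be said to give the higher inhibition in this assay.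

Compound 3, `O=C(NCc1cccnc1)c1c(O)c2cccnc2n(-c2ccccc2)c1=O`, keeps the shared core of compound 1 and changes one group: (pyridin-3-yl)methyl in place of 4-methoxyphenyl on an amide-type nitrogen. Going by the values given here, no measured step puts a (pyridin-3-yl)methyl group on that amide-type nitrogen, so the only guidance is the one step that swaps the group on this nitrogen, a number 9.3 percentage points higher from compound 1 to compound 2 (within the scatter), which stayed within the scatter. On that basis the expected step of a number 4.9 percentage points higher from compound 1 to compound 3 (within the scatter) is none beyond the scatter. Compound 3 is therefore estimated to give 3% in this assay, with a range from -10% to 16%; this estimate rests on the two numbers at hand and nothing more.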

Compound 3, a percentage reported as inhibition, in the whole organism at one dose (the size of the read-out at that dose, not a potency): 14.7%
Beside the measured number, compound 3's estimate is 11.7 percentage points below it; measured number inside the range.
By their numbers in this assay, from the lowest: compounds 1, 2 and 3 (each within the scatter of the next, the first and the last beyond it).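

For the compounds shown here, replacing 4-methoxyphenyl with (pyridin-3-yl)methyl on the amide-type nitrogen gives a number 16.6 percentage points higher from compound 1 to compound 3 (beyond the scatter) in this assay and so provides the first sign that the group at this position can move the read-out by more than the scatter, though only modestly. Replacing 3-nitrophenyl with the same group gives a number 7.3 percentage points higher from compound 2 to compound 3 (within the scatter) and so shows no separable change, which means that compound 3 stands clearly apart from compound 1 but not from compound 2. No supporting measurement at hand explains the step from compound 1 to compound 3.

The swap changes two things at once, as the entering group has a ring with a hetero atom and a carbon link to the amide-type nitrogen, so the compounds shown cannot tell which of these goes with the higher number. A plain benzyl group on that nitrogen would separate the link from the ring nitrogen, while a longer chain such as 2-(pyridin-3-yl)ethyl would show whether the length of the link matters.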